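Furan-2-yl for Thiophen-3-yl: Compound 4 Next to Compound 3

A few compounds are considered here, and "the series" means these few. Any claim that something is new, unique, unknown or untested is made for them only; others in the source may bear on it.

Measured compounds and values:
Compound 1 `Nc1nc(N)c2c(-c3ccsc3)cn([C@@H]3O[C@H](CO)[C@@H](O)[C@H]3O)c2n1` gives in a functional assay on A549 cells (Homo sapiens), read by MTT assay, with a stated time of 72 h (a lower number here means a stronger inhibitor, a higher number a weaker inhibitor), only a limit, > 100000 nM.
Compound 2 `COc1ncnc2c1c(-c1ccsc1)cn2[C@@H]1O[C@H](CO)[C@@H](O)[C@H]1O` gives in this assay 5170 nM.
Compound 3 `COc1nc(N)nc2c1c(-c1ccsc1)cn2[C@@H]1O[C@H](CO)[C@@H](O)[C@H]1O` gives in this assay only a limit, > 100000 nM.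

Compound 3 therefore sits at the edge of what this assay can report; it shares that edge with compound 1, as the limit of > 100000 nM in this assay, at which 2 of the 3 values shown sit, shows. Its neighbours tell little more. Going from compound 2 to compound 3, the step of an at least 19-fold higher number from compound 2 to compound 3 (1.28 log units; beyond the scatter) follows from amino in place of hydrogen on an aromatic carbon. Going from compound 1 to compound 3, the step that the two limits leave unreadable from compound 1 to compound 3 follows from methoxy in place of amino on an aromatic carbon.

Compound 4 `COc1nc(N)nc2c1c(-c1ccco1)cn2[C@@H]1O[C@H](CO)[C@@H](O)[C@H]1O` differs from compound 3 in one place: furan-2-yl in place of thiophen-3-yl on an aromatic carbon. Within the data shown here, none of the measured steps changes this five-membered ring, so none bears directly on the move to compound 4. Among the measured compounds shown here, the only anchor is that compound 3 reports a limit, and the change is a swap of one small five-membered aromatic ring for another of the same size. The step of a number no higher from compound 3 to compound 4 (the limit leaves the size open) is therefore expected to be none beyond the scatter. Compound 4 is estimated at 100000 nM, within 30000 nM to 300000 nM, with a limit the most likely outcome.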

Compound 4, half-maximal inhibitory concentration: > 20000 nM
Compound 4: only a limit was reported; the forecaster's own chance of this, stated with the estimate: 75%; the middle value does not contradict the limit.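

In this assay compound 4 gives only a limit, > 20000 nM, and compound 3 is also reported only as a limit, so the step between compound 3 and compound 4 cannot be read. The compounds shown leave open whether furan-2-yl in place of thiophen-3-yl changes the true number in this assay at all.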